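Working notes: from compound 3 to compound 4

The source may report more compounds than this note shows. Statements on the series, on what has been measured and on what is new or still open speak of the compounds shown alone.

In a functional assay on HL-60 cells (Homo sapiens) for cytotoxicity, read by MTT assay (a lower number here means a stronger inhibitor, a higher number a weaker inhibitor), compound 1 `O=C(N/N=C/c1ccc(F)cc1)c1cn(C2CC2)c2cc(N3CCNCC3)c(F)cc2c1=O` gives 25000 nM, compound 2 `COc1ccc(/C=N/NC(=O)c2cn(C3CC3)c3cc(N4CCNCC4)c(F)cc3c2=O)cc1O` gives 25000 nM and compound 3 `COc1cc(/C=N/NC(=O)c2cn(C3CC3)c3cc(N4CCNCC4)c(F)cc3c2=O)cc(OC)c1OC` gives 25000 nM, so compound 3 stands level with the other two. Next comes compound 4 `O=C(N/N=C/c1ccccc1O)c1cn(C2CC2)c2cc(N3CCNCC3)c(F)cc2c1=O`: 2-hydroxyphenyl in place of 3,4,5-trimethoxyphenyl on a carbon with a double bond to nitrogen, with 2-hydroxyphenyl in place of 3,4,5-trimethoxyphenyl on a carbon with a double bond to nitrogen. Three measured steps exchange the group at this same place: no change at the digits printed from compound 1 to compound 2 (within the scatter), no change at the digits printed from compound 1 to compound 3 (within the scatter) and no change at the digits printed from compound 2 to compound 3 (within the scatter). All three lie within the scatter. For the measured compounds named here, no measured compound carries 2-hydroxyphenyl, so that group remains untested. The expected result in this assay is no shift beyond the scatter: no change at the digits printed from compound 3 to compound 4 (within the scatter). The estimate for compound 4 is 25000 nM, with an expected range of 9000 nM to 35000 nM.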

Compound 4, half-maximal inhibitory concentration: 25000 nM
For compound 4 middle estimate and measured number coincide at the digits printed; measured number inside the range.
By their numbers in this assay, from the lowest: compounds 1, 2, 3 and 4 (each within the scatter of the next).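

In this assay, 2-hydroxyphenyl on a carbon with a double bond to nitrogen gives no change at the digits printed from compound 3 to compound 4 (within the scatter) and no change at the digits printed from compound 2 to compound 4 (within the scatter) and no change at the digits printed from compound 1 to compound 4 (within the scatter). The position therefore tolerates a group of 7 heavy atoms with 1 hydrogen-bond donor as well as the 12 heavy atoms and 0 donors of 3,4,5-trimethoxyphenyl, with no shift in this series. No measured evidence bears on this result. Still open, going by these compounds, is whether an aminophenyl or carboxyphenyl group at this place would shift the number. Changes elsewhere on the shared core also remain open.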